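The source may hold more compounds than are shown below. What is called first, only, known or untested is meant among the compounds shown, and "the series" means these compounds.

Values in a functional assay on A549 cells (Homo sapiens) for cytotoxicity, read by XTT assay, with a stated time of 72 h; on this read-out higher numbers stand for weaker inhibition and lower numbers for stronger inhibition:
- Compound 1 `CCCCCCCCCCCCCCCCCCc1c(O)cc(O)c(C(C)=O)c1O`: 32000 nM
- Compound 2 `CCCCCCCC/C=C\CCCCCCCCOc1cc(O)cc(O)c1C(C)=O`: > 100000 nM (a limit of the assay)
- Compound 3 `CC(C)=CCC/C=C(\C)Cc1c(OC/C=C(\C)CCC=C(C)C)c(C/C=C(\C)CCC=C(C)C)c(O)c2c(=O)cc(-c3ccccc3)oc12`: 29000 nM

In this assay only two of these compounds give a number, and compound 1 at 32000 nM and compound 3 at 29000 nM lie within the scatter of each other. Compound 2 is reported only as a limit, > 100000 nM. For the measured compounds named here, no pair of measured compounds differs in one place, so the size of any single structural change is not yet known from this series.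

The next compound to be read is compound 4 `CCCCCCCC/C=C\CCCCCCCCc1c(O)cc(O)c(C(C)=O)c1O`, which keeps the shared core of compound 1 and alters only the chain. Dec-1-en-1-yl stands in place of decyl on a saturated chain carbon, eight bonds along the chain from an aromatic carbon: dec-1-en-1-yl in place of decyl on a saturated chain carbon, eight bonds along the chain from an aromatic carbon.

Going by the values given here, with no measured step to draw on, the expectation starts from compound 1 at 32000 nM, and no shift beyond the scatter is expected in either direction. The expected step in this assay is a 1.3-fold lower number from compound 1 to compound 4 (0.11 log units; within the scatter), which stays within the scatter. For compound 4 the estimated value is 25000 nM, with an expected range of 8000 nM to 80000 nM.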

Compound 4, half-maximal inhibitory concentration: > 100000 nM
Compound 4 ended at the assay's limit; the forecaster's own chance of this, stated with the estimate: 15%; middle value at least 4.0-fold (0.60 log units) from the limit.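

In this assay compound 4 gives > 100000 nM, which is a limit of the assay and not a number. Dec-1-en-1-yl in place of decyl, on a saturated chain carbon, eight bonds along the chain from an aromatic carbon, gives an at least 3.1-fold higher number from compound 1 to compound 4 (0.49 log units; beyond the scatter); this is the first single-place step in the series, and it shows that the read-out responds to a change at this position even though heavy atoms, rings, hydrogen-bond donors and acceptors and net charge stay the same in the counts for the two groups. The size of this step is bounded on one side only, and the result joins another value at the same ceiling: the limit of > 100000 nM in this assay, at which 2 of the 4 values shown sit.

From the compounds shown here alone, how far compound 4 lies beyond the limit stays open, so the full size of the step cannot be read from this assay. Also open, going by these compounds, is how a longer chain, or a carboxylic acid or an amine in place of dec-1-en-1-yl at this same place on the core of compound 1, would read in this assay.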